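A few compounds are considered here, and "the series" means these few. Any claim that something is new, unique, unknown or untested is made for them only; others in the source may bear on it.

Measured so far in an assay on THP-1 cells for displacement of a labelled ligand from C-C chemokine receptor type 1 (Homo sapiens); a higher number here means a weaker inhibitor, a lower number a stronger inhibitor:
compound 1 `CC(C)[C@@H](NC(=O)c1nc2ccccc2s1)C(=O)N1CCC(c2ccc(Cl)cc2)CC1` gives 18 nM
compound 2 `CC(C)C(NC(=O)c1ccc2ccccc2c1)C(=O)N1CCC(c2ccc(Cl)cc2)CC1` gives 80 nM
compound 3 `CCCC(NC(=O)c1ccccc1C)C(=O)N1CCC(c2ccc(Cl)cc2)CC1` gives 152 nM

Compound 1 holds the lowest number of the three. Its gap to compound 2 and its larger gap to compound 3 in this assay both lie beyond the usual scatter, so on these numbers compound 1 is the strongest inhibitor of the set. Among the measured compounds shown here, compound 2 and compound 3 each differ from compound 1 in more than one place, so no single-point step has been measured.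

Compound 4 `CC(C)[C@@H](NC(=O)NCc1ccccc1)C(=O)N1CCC(c2ccc(Cl)cc2)CC1` has not yet been measured. Relative to compound 1 the change is benzylamino in place of 1,3-benzothiazol-2-yl on a carbonyl carbon. For the measured compounds named here, no measured pair isolates this exchange. Every variation of the acyl group seen so far has given a higher number than compound 1: compound 2 gives 80 nM and compound 3 gives 152 nM. On that basis a weakening step beyond the scatter is expected here too, with the benzylamino urea taken to fall in the range of those weaker analogues. Compound 4 is therefore expected at about 150 nM, within 40 nM to 600 nM. This corresponds to an expected step of an 8.3-fold higher number from compound 1 to compound 4 (0.92 log units; beyond the scatter).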

Compound 4, half-maximal inhibitory concentration: 180 nM
Beside the measured number, compound 4's estimate is 1.2-fold (0.08 log units) below it; measured number inside the range.
By their numbers in this assay, from the lowest: compound 1; then compounds 2, 3 and 4 (each within the scatter of the next, the first and the last beyond it).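

In this assay, compound 1 and compound 4 differ in one place only, so a 10-fold higher number from compound 1 to compound 4 (1.00 log units; beyond the scatter) gives the series its first measured effect of an exchange on the carbonyl carbon with the rest of the structure held constant. The earlier compounds shown here changed more than one place at once, whereas this pair shows that replacing 1,3-benzothiazol-2-yl with benzylamino is enough on its own to give a step beyond the scatter. This exchange changes the ring count, hydrogen-bond donors and hydrogen-bond acceptors together, and no evidence is available that separates their contributions.

On these data alone, it remains open whether the step follows the urea nitrogen or the change of aromatic group. A phenylacetyl group or a 1,3-benzoxazol-2-yl group on the same carbonyl carbon would help to separate these two changes.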